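The source may report more compounds than this note shows. Statements on the series, on what has been measured and on what is new or still open speak of the compounds shown alone.

Measured in a functional assay on CCRF-CEM cells (Homo sapiens), with a stated time of 72 h; on this read-out higher numbers stand for weaker inhibition and lower numbers for stronger inhibition:
compound 1, `O=C1/C(=N\NC(=S)Nc2ccc(Cl)cc2)c2cc(F)ccc2N1Cc1ccc(F)cc1`, gives 56000 nM
compound 2, `O=C1/C(=N\NC(=S)Nc2ccc(Cl)cc2)c2cc(Cl)ccc2N1Cc1ccc(F)cc1`, gives 50000 nM
compound 3, `Cc1ccc(NC(=S)N/N=C2\C(=O)N(Cc3ccc(F)cc3)c3ccc(Br)cc32)cc1`, gives 132000 nM

Compound 3 shows the highest of the three numbers; the difference between its core and the core of compound 1 is not broken down here. Between compound 1 and compound 2 the change is chloro in place of fluoro on an aromatic carbon, and it gives a 1.1-fold lower number from compound 1 to compound 2 (0.05 log units; within the scatter). Compound 4, `Cc1ccc(NC(=S)N/N=C2\C(=O)N(Cc3ccc(Cl)cc3)c3ccc(Br)cc32)cc1`, is not yet measured; it differs from compound 3 by chloro in place of fluoro on an aromatic carbon. This is the same kind of change as that from compound 1 to compound 2, not the same: there the place is part of a fused or bridged system of two rings, meta to a fused ring and para to a fused ring, here it is para to a large group. In this assay the step from compound 3 to compound 4 is expected to be small, a 1.1-fold lower number from compound 3 to compound 4 (0.04 log units; within the scatter), because a 1.1-fold lower number from compound 1 to compound 2 (0.05 log units; within the scatter) stayed within the scatter. Compound 4 is therefore estimated at 120000 nM, with a range from 55000 nM to 260000 nM.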

Compound 4, half-maximal inhibitory concentration: >= 500000 nM
Compound 4 gave a limit, no number (the forecaster's own chance of this, stated with the estimate: 15%); middle value at least 4.1-fold (0.61 log units) away from the limit.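

In this assay compound 4 gives >= 500000 nM, which is a limit of the assay and not a number, so only a bound on the step can be read: the limit of >= 500000 nM in this assay, at which 1 of the 4 values shown sits.

The step is an at least 3.7-fold higher number from compound 3 to compound 4 (0.57 log units; beyond the scatter), and chloro in place of fluoro therefore does not carry over unchanged from one core to the other: the same change on two cores in this assay, a 1.1-fold lower number (0.05 log units; within the scatter) from compound 1 to compound 2 and an at least 3.7-fold higher number (0.57 log units; beyond the scatter) from compound 3 to compound 4, at least 4.2-fold (0.62 log units) apart, beyond the scatter of two such steps.

This does not show what sets the two steps apart, since compound 1 and compound 2 carry the change on a fused system of two rings, whereas compound 3 and compound 4 carry it as 4-fluorobenzyl to 4-chlorobenzyl, on a different core.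

Open, on these data alone, is how 4-fluorobenzyl to 4-chlorobenzyl reads on the core of compound 1. Also open, as far as these compounds go, is how methoxy or a carboxylic acid would read in that place.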